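The compounds below may be only part of what the source reports. "The series", "measured", "known", "first", "only" and "open" are said of these compounds alone.

Of the compounds shown here, two sharing one core have been measured in a functional assay on KB cells (Homo sapiens) for cytotoxicity; a lower number here means that less compound is needed, a higher number that more compound is needed for the effect. Compound 1 `CCC[C@@H](OC(C)=O)C1=C(Br)/C(=C/Br)OC1=O` gives 0.8 ug/mL there, and compound 2 `CCC[C@@H](O)C1=C(Br)/C(=C/I)OC1=O` gives 0.4 ug/mL in this assay, the lower of the two numbers, although the gap to compound 1 lies within the usual scatter. Compound 3 `CCC[C@@H](O)C1=C(Br)/C(=C/Br)OC1=O` has not yet been measured; it differs from compound 2 by bromo in place of iodo on a double-bonded chain carbon bound to a double-bonded ring carbon. Nothing measured here isolates such a swap, so only a small step is expected, a 1.5-fold higher number from compound 2 to compound 3 (0.18 log units; within the scatter), none beyond the scatter. Compound 3 is estimated at 0.6 ug/mL in this assay, most likely between 0.25 ug/mL and 1.5 ug/mL.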

Compound 3, concentration for half-maximal effect: 0.4 ug/mL
For compound 3 the middle estimate is 1.5-fold (0.18 log units) above the measured one; measured number inside the range.
By their numbers in this assay, from the lowest: compounds 2, 3 and 1 (each within the scatter of the next).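

In this assay, bromo in place of iodo on a double-bonded chain carbon bound to a double-bonded ring carbon shows no change at the digits printed from compound 2 to compound 3 (within the scatter), so this position takes either halogen with no readable shift. Hydrogen in place of acetyl on an oxygen on a saturated carbon, now seen as a change on its own, shows a 2.0-fold lower number from compound 1 to compound 3 (0.30 log units; within the scatter), so these two forms cannot be told apart here. No measured evidence offers a reason for either step. Going by these compounds, whether an amine on that double-bonded chain carbon, or a benzoyl group on that oxygen, would move the number stays open.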